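Swapping the Five-Membered Ring of Compound 3

The source may hold more compounds than are shown below. What is called first, only, known or untested is meant among the compounds shown, and "the series" means these compounds.

Compound 1 `N#C/C(=C\c1ccc(Cl)cc1)C(=O)c1ccc[nH]1` gives 27000 nM in a functional assay on MCF7 cells (Homo sapiens) for inhibition, read by MTT assay, with a stated time of 72 h; on this read-out lower numbers stand for stronger inhibition of growth and higher numbers for weaker inhibition of growth.
Compound 2 `N#C/C(=C\c1c[nH]c2ccccc12)C(=O)c1c[nH]c2ccccc12` gives 11000 nM in this assay.
Compound 3 `COc1ccc(CNC(=O)/C(C#N)=C/c2ccc[nH]2)cc1` gives 34000 nM in this assay.

Among these three, compound 3 carries the highest number in this assay. Its nearest neighbour is compound 1, whose number lies within the scatter of repeated measurements, so the two cannot be ranked against each other. Compound 2 stands furthest from compound 3, with a gap beyond the scatter, and is therefore the stronger inhibitor of growth of that pair.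

Compound 4 `COc1ccc(CNC(=O)/C(C#N)=C/c2ccoc2)cc1` differs from compound 3 in one place: furan-3-yl in place of 1H-pyrrol-2-yl on a double-bonded chain carbon bound to a double-bonded chain carbon. Within the data shown here, no two measured compounds differ in exactly one place, so no measured step guides this change directly. All three measured numbers in this assay sit high, and the change exchanges one five-membered aromatic ring with 1 hetero atom for another described in the same terms. For compound 4 the expected step of a 1.2-fold higher number from compound 3 to compound 4 (0.07 log units; within the scatter) is none beyond the scatter, in either direction. Compound 4 is estimated at 40000 nM in this assay, with a range from 15000 nM to 110000 nM.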

Compound 4, concentration for 50% growth inhibition: 7000 nM
Estimate against measurement, compound 4: 5.7-fold (0.76 log units) above; measured number outside the range, below it.
By their numbers in this assay, from the lowest: compounds 4 and 2 (each within the scatter of the next); then compounds 1 and 3 (each within the scatter of the next).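

Among these compounds, the exchange of 1H-pyrrol-2-yl for furan-3-yl on a double-bonded chain carbon bound to a double-bonded chain carbon gives a 4.9-fold lower number from compound 3 to compound 4 (0.69 log units; beyond the scatter) in this assay and is the first step here between compounds that differ in one place. It shows that this place is not indifferent to which five-membered aromatic ring with 1 hetero atom it carries, even though both groups have 5 heavy atoms. The groups differ in their hetero atom, nitrogen or oxygen, and in their counts, with 1 hydrogen-bond donor and 0 hydrogen-bond acceptors leaving and 0 hydrogen-bond donors and 1 hydrogen-bond acceptor entering, but no measurement shown here accounts for the step.

A single pair cannot separate the identity of the hetero atom from its attachment to the ring. The compounds shown leave open how furan-2-yl, 1H-pyrrol-3-yl or thiophen-3-yl would read at this place.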